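This account rests on a few compounds, and the source may have more. Where it says the series, first, only, none or still open, it means among the compounds named here.

Compound 1 `Cc1ccc2c(NCc3ccc(NC(=O)C4CCN(C(=O)OC(C)(C)C)CC4)cc3)nc(N(C)C)nc2c1` is measured in a functional assay on SV5A8 cells (Homo sapiens) for cytotoxicity; a higher number here means a weaker inhibitor, a lower number a stronger inhibitor. In this assay compound 1 gives > 4820 nM, which is a limit of the assay and not a number (the limit of > 4820 nM in this assay, at which 1 of the 2 values shown sits). Compound 2 `Cc1ccc2c(NCc3ccc(NC(=O)C4CCN(Cc5ccccc5)CC4)cc3)nc(N3CCC(N4CCCC4)CC3)nc2c1` in this assay gives > 8090 nM, again only a limit (the limit of > 8090 nM in this assay, at which 1 of the 2 values shown sits). Compound 3 `Cc1ccc2c(NCc3ccc(NC(=O)C4CCN(C5CCCCC5)CC4)cc3)nc(N(C)C)nc2c1` differs from compound 1 by cyclohexyl in place of tert-butoxycarbonyl on an amine nitrogen in a ring. Among the compounds with values here, no measured pair shows what this swap does, so a step no larger than the usual scatter is expected, in either direction. Compound 3 is therefore estimated at 8000 nM, between 3000 nM and 30000 nM. The expected step is a step that the limit leaves unreadable from compound 1 to compound 3.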

Compound 3, half-maximal inhibitory concentration: > 8320 nM
Compound 3: a limit, no number; the forecaster's own chance of this, stated with the estimate: 70%; middle value at least 1.0-fold (0.01 log units) from the limit.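

Compound 1 and compound 3 both give only limits of the assay, not numbers, so the step from tert-butoxycarbonyl to cyclohexyl cannot be read. The compounds shown leave open what this swap does and how strong any of these inhibitors actually is.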